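The source may report more compounds than this note shows. Statements on the series, on what has been measured and on what is new or still open speak of the compounds shown alone.

Measured so far in an ADME assay on HEK293 cells (Homo sapiens) for cytotoxicity, with a stated time of 72 h; on this read-out higher numbers stand for an effect only at larger amounts of compound and lower numbers for an effect already at smaller amounts:
Compound 1 `C=C[C@@](C)(/C=C/c1ccc(O)c(/C=C/C(=O)OCc2ccccc2)c1)CCC=C(C)C`: > 36600 nM (a limit)
Compound 2 `C=C[C@@](C)(/C=C/c1ccc(O)c(/C=C/c2ccc(Cl)cc2)c1)CCC=C(C)C`: > 36600 nM (a limit)
Compound 3 `COc1ccc(/C=C/[C@@](C)(/C=C/c2ccc(O)c(C=O)c2)CCC=C(C)C)cc1`: 2270 nM

Within the data shown here, compound 3 holds the only actual number in this assay, at 2270 nM. Compound 1 and compound 2 both stand at the limit of > 36600 nM in this assay, at which 2 of the 3 values shown sit. Among the measured compounds shown here, the one measured step, a step that the two limits leave unreadable from compound 1 to compound 2, gives no size that could be carried over to a new change.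

Compound 4 `COc1ccc(/C=C/[C@@](C)(/C=C/c2ccc(O)c(/C=C/C(=O)c3ccccc3)c2)CCC=C(C)C)cc1` is the next to be measured. It carries 2-benzoylethenyl in place of formyl on an aromatic carbon, ortho to a hydroxy group: 2-benzoylethenyl in place of formyl on an aromatic carbon.

Where compound 3 has formyl, compound 2 carries 4-chlorophenyl on a double-bonded chain carbon, and its limit stands at > 36600 nM. That compound also differs from compound 3 elsewhere, so this limit is only a loose guide to the present change. On that basis a move toward larger concentrations is expected, modestly beyond the scatter and with its size poorly fixed. The estimated step is a 3.1-fold higher number from compound 3 to compound 4 (0.49 log units; beyond the scatter). For compound 4 the estimate is 7000 nM, with an expected range from 1500 nM to 30000 nM.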

Compound 4, half-maximal effective concentration: > 36600 nM
Compound 4: a limit, no number (the forecaster's own chance of this, stated with the estimate: 25%); middle value at least 5.2-fold (0.71 log units) away from the limit.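

In this assay, the aromatic carbon ortho to a hydroxy group is now shown to matter: putting 2-benzoylethenyl in place of formyl there gives an at least 16-fold higher number from compound 3 to compound 4 (1.20 log units; beyond the scatter), a step beyond the usual scatter. Among these compounds, the earlier compounds could not show this, as compound 3 differs from compound 1 and compound 2 in more than one place, whereas compound 3 and compound 4 differ only in this group, so the one actual number in the set goes with formyl within this pair. Compound 4 itself gives > 36600 nM, which is a limit and not a number, and the series now rests largely on that limit: the limit of > 36600 nM in this assay, at which 3 of the 4 values shown sit.

On these data alone, how far the step really reaches stays open, as does whether it follows the loss of formyl or the entry of the larger 2-benzoylethenyl group with its six-membered aromatic ring. The compounds shown also do not tell whether a small group such as hydroxymethyl, a carboxylic acid or an aminomethyl at this position would stay close to compound 3 or reach the limit.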